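The source may report more compounds than this note shows. Statements on the series, on what has been measured and on what is new or still open speak of the compounds shown alone.

Of the compounds shown here, three built on a shared core have been measured in a functional assay on HL-60 cells (Homo sapiens) for antiproliferative activity, read by MTT assay, with a stated time of 72 h; a higher number here means a weaker inhibitor, a lower number a stronger inhibitor. Compound 1 (`COc1cc(C(=O)c2sc3ccccc3c2-c2ccc(Cl)cc2)cc(OC)c1OC`) gives 3300 nM, compound 2 (`COc1cc(C(=O)c2sc3ccccc3c2Nc2ccc(C)cc2)cc(OC)c1OC`) gives 4600 nM, and compound 3 (`CCOc1ccc(Nc2c(C(=O)c3cc(OC)c(OC)c(OC)c3)sc3ccccc23)cc1`) gives 500 nM. Compound 3 has the lowest number of the three, and its gaps to both others lie beyond the scatter. The other two do not separate, with a 1.4-fold higher number from compound 1 to compound 2 (0.14 log units; within the scatter). The steps that reach compound 3 are modest: a 6.6-fold lower number from compound 1 to compound 3 (0.82 log units; beyond the scatter) and a 9.2-fold lower number from compound 2 to compound 3 (0.96 log units; beyond the scatter), the second being ethoxy in place of methyl on an aromatic carbon.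

Compound 4 (`CCOc1ccc(Nc2c(C(=O)c3cc(OC)c(OC)c(OC)c3)sc3cc(C)ccc23)cc1`) departs from compound 3 in one place, with methyl in place of hydrogen on an aromatic carbon. Within the data shown here, none of the measured steps alters the position where this methyl enters, so the data hold no direct precedent for the change. The modest steps above come from a different part of the molecule and give no guide to direction. No step beyond the scatter is therefore expected in this assay. The expected outcome is a 1.1-fold lower number from compound 3 to compound 4 (0.05 log units; within the scatter). The estimate for compound 4 is 450 nM, with an expected range from 120 nM to 1800 nM.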

Compound 4, half-maximal inhibitory concentration: 4000 nM
For compound 4 the middle estimate is 8.9-fold (0.95 log units) below the measured one; measured number outside the range, above it.
By their numbers in this assay, from the lowest: compound 3; then compounds 1, 4 and 2 (each within the scatter of the next).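

Among these compounds, compound 4 gives the first reading at this position of the shared core, an aromatic carbon of a six-membered aromatic ring of carbon only, part of a fused or bridged system of two rings, and in this assay the position proves not to be indifferent to substitution: methyl in place of hydrogen gives an 8.0-fold higher number from compound 3 to compound 4 (0.90 log units; beyond the scatter) on the scale of this series. The entering group holds one heavy atom, yet the step is of much the same modest size as a 9.2-fold lower number from compound 2 to compound 3 (0.96 log units; beyond the scatter) and runs the opposite way, so the gain seen with compound 3 does not survive this small addition. No measurement in hand bears on why the methyl has this effect.

From the compounds shown here alone, this is one group at one carbon on one background, so it remains open whether a fluorine, a hydroxyl or an amine at the same carbon would bring the same loss, or whether only methyl does. Also open, going by these compounds, is whether methyl on the other carbons of that ring would behave in the same way, and whether the same change would matter on the background of compound 2.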